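Working notes: from compound 2 to compound 3

A few compounds are considered here, and "the series" means these few. Any claim that something is new, unique, unknown or untested is made for them only; others in the source may bear on it.

Values in a functional assay on DU-145 cells (Homo sapiens) for inhibition, read by trypan blue exclusion, with a stated time of 96 h; on this read-out higher numbers stand for weaker inhibition of growth and lower numbers for stronger inhibition of growth
Compound 1 `COc1ccc(/C=C(/SCc2ccc(F)cc2)C(=O)c2ccc(Br)cc2)cc1` 50000 nM
Compound 2 `O=C(/C(=C\c1ccc(Br)cc1)SCc1ccc(F)cc1)c1ccc(Br)cc1` 25000 nM

Compound 2 (25000 nM) stands within the scatter of compound 1 (50000 nM), so the two do not separate. Compound 3 `O=C(/C(=C\c1ccc2ccccc2n1)SCc1ccc(F)cc1)c1ccc(Br)cc1` is next: quinolin-2-yl in place of 4-bromophenyl on a double-bonded chain carbon bound to a double-bonded chain carbon gives quinolin-2-yl in place of 4-bromophenyl. Within the data shown here, the only measured step, a 2.0-fold lower number from compound 1 to compound 2 (0.30 log units; within the scatter), swapped bromo for methoxy on an aromatic carbon and gives little guidance for replacing a whole group. The expected 2.5-fold lower number from compound 2 to compound 3 (0.40 log units; beyond the scatter) is therefore a modest move to a lower number, held with little confidence. Compound 3 is estimated at 10000 nM with an expected range from 1500 nM to 50000 nM in this assay for now.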

Compound 3, concentration for 50% growth inhibition: 25000 nM
For compound 3 the middle estimate is 2.5-fold (0.40 log units) below the measured one; the measured number falls inside the stated range.
By their numbers in this assay, from the lowest: compounds 2, 3 and 1 (each within the scatter of the next).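

At the double-bonded chain carbon bound to a double-bonded chain carbon, replacing the whole aryl group now joins the earlier single-substituent swap. In this assay quinolin-2-yl in place of 4-bromophenyl gives no change at the digits printed from compound 2 to compound 3 (within the scatter) and quinolin-2-yl in place of 4-methoxyphenyl gives a 2.0-fold lower number from compound 1 to compound 3 (0.30 log units; within the scatter), so the added ring and ring nitrogen do not separate compound 3 from either compound. No evidence accompanying this result speaks to its origin.

From the compounds shown here alone, it remains open whether any group here moves the number beyond the scatter. An amine or a carboxylic acid at this place would test that beyond aromatic rings.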